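This account rests on a few compounds, and the source may have more. Where it says the series, first, only, none or still open, it means among the compounds named here.

Measured compounds in a functional assay on Bel-7402 cells (Homo sapiens) for cytotoxicity, read by MTT assay; a higher number here means a weaker inhibitor, a lower number a stronger inhibitor:

compound 1 `COc1ccc(/C=C/C(=O)c2sc(Nc3ccc(Cl)cc3)nc2C)cc1`: > 25000 nM, a limit of the assay, not a number.
compound 2 `Cc1nc(Nc2ccc(Cl)cc2)sc1C(=O)/C=C/c1ccccc1`: > 25000 nM, a limit of the assay, not a number.
compound 3 `Cc1nc(Nc2ccc(Cl)cc2)sc1C(=O)/C=C/c1ccc(Cl)cc1`: > 25000 nM, a limit of the assay, not a number.

Compound 2 stands only at a limit in this assay, and the two further values shown are limits as well, so its place among them cannot be read. The steps a step that the two limits leave unreadable from compound 1 to compound 2, a step that the two limits leave unreadable from compound 1 to compound 3 and a step that the two limits leave unreadable from compound 2 to compound 3 are all unreadable in size, (the limit of > 25000 nM in this assay, at which 3 of the 3 values shown sit).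

Compound 4 `Cc1ccc(Nc2nc(C)c(C(=O)/C=C/c3ccccc3)s2)cc1` differs from compound 2 by methyl in place of chloro on an aromatic carbon. None of the three measured steps touches this aromatic carbon; all three alter a substituent elsewhere in the molecule, and none gives a readable size. Going by the values given here, no measured step therefore bears on the change, and no direction can be argued from the data; the only expectation is that compound 4 remains where the whole series sits, at the limit of this assay.

Compound 4 is estimated at 35000 nM, with a range from 12000 nM to 100000 nM, most probably reported as a limit again. The step this estimate means is a step that the limit leaves unreadable from compound 2 to compound 4.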

Compound 4, half-maximal inhibitory concentration: > 25000 nM
Compound 4 ended at the assay's limit; the forecaster's own chance of this, stated with the estimate: 85%; the middle value is on the limit's open side.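

No new step can be read between compound 2 and compound 4, as both values are limits and not numbers: the limit of > 25000 nM in this assay, at which 4 of the 4 values shown sit.

The compounds shown leave open whether any change to the shared core gives a measurable value in this assay.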